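The source may report more compounds than this note shows. Statements on the series, on what has been measured and on what is new or still open speak of the compounds shown alone.

Measured compounds:
- compound 1 `O=C1/C(=C/c2ccccc2)NS(=O)(=O)c2ccccc21` with 1780 nM
- compound 2 `O=C1/C(=C/c2ccc(Br)cc2)NS(=O)(=O)c2ccccc21` with 3690 nM

Two compounds share one core and differ only in the ring hanging from the double-bonded chain carbon. In an assay for inhibition of Intestinal-type alkaline phosphatase (Homo sapiens), read by spectrophotometry, with stated times of 10 min and 20 min (on this read-out lower numbers stand for stronger inhibition and higher numbers for weaker inhibition), compound 1 gives 1780 nM, and compound 2 gives 3690 nM. Within the data shown here, compound 2 thus holds the higher of the two numbers, the weaker inhibition, and the only measured step, a 2.1-fold higher number from compound 1 to compound 2 (0.32 log units; beyond the scatter), is modest but beyond the scatter.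

Compound 3 `O=C1/C(=C/c2cccc(Cl)c2)NS(=O)(=O)c2ccccc21` has not yet been measured. Its change from compound 2 is 3-chlorophenyl in place of 4-bromophenyl on a double-bonded chain carbon bound to a double-bonded ring carbon. Among the measured compounds shown here, no measured step covers this exchange: the one known step swaps hydrogen for bromo, whereas here one halogen-bearing ring is traded for another halogen-bearing ring of the same size. With nothing else to go on, compound 3 is expected to land close to compound 2, with the step of a 1.5-fold lower number from compound 2 to compound 3 (0.17 log units; within the scatter) as the estimate. The expected value for compound 3 is 2500 nM, with a range from 1000 nM to 6500 nM.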

Compound 3, half-maximal inhibitory concentration: 3770 nM
Beside the measured number, compound 3's estimate is 1.5-fold (0.18 log units) below it; measured number inside the range.
By their numbers in this assay, from the lowest: compound 1; then compounds 2 and 3 (each within the scatter of the next).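

In this assay, putting 3-chlorophenyl in place of 4-bromophenyl on the double-bonded chain carbon gives a 1.0-fold higher number from compound 2 to compound 3 (0.01 log units; within the scatter), so changing both the halogen and its place on the ring produces no readable difference here. Compared with the bare phenyl ring of compound 1, the chlorine-bearing ring gives a 2.1-fold higher number from compound 1 to compound 3 (0.33 log units; beyond the scatter), a modest step much like a 2.1-fold higher number from compound 1 to compound 2 (0.32 log units; beyond the scatter), so both halogen-bearing rings now sit on the weaker side of compound 1, and the earlier bromo result no longer stands alone. No measurement available here explains why these two rings read alike.

Because the halogen and its place changed together, the two changes cannot be separated: 3-bromophenyl or 4-chlorophenyl would be needed to show whether they have no effect or merely offset each other. The compounds shown also leave open how this position responds to groups other than halogens, such as an amine, a methoxy group or a carboxylic acid on the same ring.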